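Swapping the aminomethyl for a 2-hydroxyethoxy group

The source may report more compounds than this note shows. Statements on the series, on what has been measured and on what is new or still open speak of the compounds shown alone.

Measured so far:
compound 1, `Cc1ccsc1-c1ccc(C(=O)Nc2c(C)cc(CO)cc2C)o1`, 90%
compound 2, `Cc1cc(CN)cc(C)c1NC(=O)c1ccc(-c2cc(Cl)ccc2Cl)o1`, 90%

The two measured compounds share a furan-amide core and differ in their outer groups. In an assay on isolated protein for inhibition of sphingosine 1-phosphate receptor 2 (Homo sapiens), tested at 25 uM (a lower number here means less inhibition, a higher number more inhibition at the concentration tested (going by the name of the read-out)), compound 1 gives 90%. In this assay compound 2 gives 90%, a value level with that of compound 1 at the digits reported, so no difference beyond the usual scatter can be read between them. Within the data shown here, no single-point step between measured compounds is available, so the two values only show that both compounds inhibit strongly at the concentration tested.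

Compound 3, `Cc1cc(OCCO)cc(C)c1NC(=O)c1ccc(-c2cc(Cl)ccc2Cl)o1`, has not yet been measured in this assay. It differs from compound 2 in one place: 2-hydroxyethoxy in place of aminomethyl on an aromatic carbon. Because compound 2 already sits at 90%, and compound 1 reaches the same level with a different group at that place, the change is expected to move the read-out little, with at most a modest fall. The step from compound 2 to compound 3 is estimated as a number 5 percentage points lower from compound 2 to compound 3 (within the scatter). Compound 3 is therefore expected to give about 85%, with a likely range from 65% to 98%.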

Compound 3, a percentage reported as inhibition, at one concentration (the size of the read-out at that concentration, not a potency): 90%
Estimate against measurement, compound 3: 5 percentage points below; the measured number falls inside the stated range.
By their numbers in this assay, from the lowest: compounds 1, 2 and 3 (each within the scatter of the next).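

In this assay the exchange of aminomethyl for 2-hydroxyethoxy gives no change at the digits printed from compound 2 to compound 3 (within the scatter) with the rest of the molecule held constant. Among these compounds, this is the first comparison that isolates this position, on an aromatic carbon para to a large group, since compound 1 and compound 2 differ in more than one place and their matching values could not be tied to any single group. The position therefore accepts a larger group with oxygen in place of the nitrogen without a visible loss at this one concentration, although nothing shown here explains why the read-out holds.

Still open, as far as these compounds go, is whether a carboxylic acid, a plain methoxy group or a longer chain such as 3-hydroxypropoxy at the same place would keep the inhibition at this level, and whether a bare hydrogen there would do so too. Also open, from the compounds shown here alone, is whether compound 2 and compound 3 would still match in potency across a range of concentrations, which a single-concentration read-out cannot tell.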